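Cytotoxicity series: amide-linked piperidines, ethoxy for bromo

The source may hold more compounds than are shown below. What is called first, only, known or untested is meant among the compounds shown, and "the series" means these compounds.

Compound 3 `O=C(c1cc(-c2cccc(Br)c2)nc2ccccc12)N1CCC(Cc2ccccc2)CC1` sits at the upper limit of an ADME assay on HepG2 2.2.15 cells (Homo sapiens) for cytotoxicity, read by MTT assay, with stated times of 3 days and 7 days (on this read-out higher numbers stand for lower toxicity in this test and lower numbers for higher toxicity in this test), rather than at a number: in this assay compound 3 gives > 20000 nM, a limit. Compound 1 `CC(C)Cc1ccc(-c2cc(C(=O)N3CCC(Cc4ccccc4)CC3)c3ccccc3n2)cc1` likewise gives only a limit in this assay, > 20000 nM. Compound 2 `O=C(c1cc(-c2ccsc2Cl)nc2ccccc12)N1CCC(Cc2ccccc2)CC1` also gives only a limit in this assay, > 20000 nM. All three values shown share (the limit of > 20000 nM in this assay, at which 3 of the 3 values shown sit), so the step from compound 1 to compound 2 is a step that the two limits leave unreadable from compound 1 to compound 2, the step from compound 1 to compound 3 is a step that the two limits leave unreadable from compound 1 to compound 3, and the step from compound 2 to compound 3 is a step that the two limits leave unreadable from compound 2 to compound 3; none of them can be sized from the numbers shown.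

Compound 4 `CCOc1cccc(-c2cc(C(=O)N3CCC(Cc4ccccc4)CC3)c3ccccc3n2)c1` differs from compound 3 by ethoxy in place of bromo on an aromatic carbon. Going by the values given here, no measured step bears on this change in a readable way, since every step so far runs between two limits. The three aryl variations shown, including a thiophene and two differently substituted phenyl rings, all left the read-out at the limit, which gives no reason to expect an ethoxy group to move it off that limit. The step from compound 3 to compound 4 is therefore expected to be a step that the limit leaves unreadable from compound 3 to compound 4, that is none beyond the scatter. For compound 4 in this assay the estimate is 30000 nM, with a range from 15000 nM to 60000 nM, most likely reported again only as a limit.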

Compound 4, half-maximal cytotoxic concentration: > 20000 nM
Compound 4 gave a limit, no number; the forecaster's own chance of this, stated with the estimate: 85%; the middle value lies beyond the limit too.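

In this assay compound 4 gives > 20000 nM, a limit and not a number. The steps to compound 4 from compound 1, compound 2 and compound 3 therefore cannot be read, as the series stays at one shared limit: the limit of > 20000 nM in this assay, at which 4 of the 4 values shown sit. The compounds shown leave open whether any aryl group on the shared core gives a measurable cytotoxic concentration.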